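A few compounds are considered here, and "the series" means these few. Any claim that something is new, unique, unknown or untested is made for them only; others in the source may bear on it.

Going by the values given here, compound 1 `CCC(=O)N[C@@H](C)c1ccc(NC(=O)[C@H]2C[C@@H]2c2cccnc2)cc1` gives 54000 nM in a physicochemical assay for solubility, at pH 6.8 (on this read-out lower numbers stand for lower solubility and higher numbers for higher solubility), and compound 2 `COCC(=O)N[C@@H](C)c1ccc(NC(=O)[C@H]2C[C@@H]2c2cccnc2)cc1` gives 520000 nM, the higher of the two numbers so far. Among the compounds with values here, the only measured step is a 9.6-fold higher number from compound 1 to compound 2 (0.98 log units; beyond the scatter), a modest one beyond the scatter, with methoxy in place of methyl on a saturated chain carbon bound to a carbonyl carbon. Compound 3 `C[C@H](NC(=O)[C@@H]1CCCN1C)c1ccc(NC(=O)[C@H]2C[C@@H]2c2cccnc2)cc1` changes the same side of the molecule, with 1-methylpyrrolidin-2-yl in place of methoxymethyl on a carbonyl carbon. Within the data shown here, that single step bears on this change only loosely, as it swaps a different group, and no measured compound carries a ring on that carbonyl carbon. The expected change in this assay therefore leans upward but is not expected to pass the scatter: a 1.5-fold higher number from compound 2 to compound 3 (0.19 log units; within the scatter). Compound 3 is estimated at 800000 nM, with an expected range of 250000 nM to 2500000 nM.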

Compound 3, solubility: 730000 nM
Beside the measured number, compound 3's estimate is 1.1-fold (0.04 log units) above it, within the range that was stated.
By their numbers in this assay, from the lowest: compound 1; then compounds 2 and 3 (each within the scatter of the next).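

Going by these compounds alone, on the carbonyl carbon whose other neighbour is the amide-type nitrogen, a ring now stands for the first time. In this assay, 1-methylpyrrolidin-2-yl in place of methoxymethyl gives no separation between the two groups (a 1.4-fold higher number from compound 2 to compound 3 (0.15 log units; within the scatter)), while the same ring in place of ethyl gives a large step (a 14-fold higher number from compound 1 to compound 3 (1.13 log units; beyond the scatter)). This position therefore takes two quite different groups, an open chain with an oxygen and a five-membered ring with a nitrogen, and both compound 2 and compound 3 lie beyond the scatter from compound 1. No measurement shown offers a reason for these numbers.

On these data alone, whether an open-chain amine such as dimethylaminomethyl, or a ring without nitrogen such as cyclopentyl, would read like compound 3 remains open. So does the effect of the opposite configuration at the defined stereocentre of the 1-methylpyrrolidin-2-yl group.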